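Carboxymethyl in place of bromo: compound 2 to compound 4

The source may hold more compounds than are shown below. What is called first, only, known or untested is meant among the compounds shown, and "the series" means these compounds.

The three measured compounds share one core and differ only in the aromatic group on the amine nitrogen. Compound 1 `CC1CC/C(=N\Nc2ccccc2F)c2ncc(C(=O)O)c(=O)n21` in a functional assay on the whole organism for inhibition, with Rattus norvegicus as the target (a higher number here means that more compound is needed for the effect, a lower number that less compound is needed), gives > 1000 umol/kg, which is a limit of the assay and not a number. Compound 2 `CC1CC/C(=N\Nc2ccc(Br)cc2)c2ncc(C(=O)O)c(=O)n21` in this assay gives > 1000 umol/kg, again only a limit. Compound 3 `Cc1cccc(N/N=C2\CCC(C)n3c2ncc(C(=O)O)c3=O)c1` in this assay gives 72.5 umol/kg. The step that the two limits leave unreadable from compound 1 to compound 2 is therefore unreadable, while an at least 13-fold lower number from compound 1 to compound 3 (1.13 log units; beyond the scatter) and an at least 13-fold lower number from compound 2 to compound 3 (1.13 log units; beyond the scatter) are both large and in the same direction.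

Compound 2 thus stands at the weaker end of what has been seen, sharing the limit of > 1000 umol/kg in this assay, at which 2 of the 3 values shown sit, with compound 1; nothing more precise about it is known.

Compound 4 `CC1CC/C(=N\Nc2ccc(CC(=O)O)cc2)c2ncc(C(=O)O)c(=O)n21` is the next variation: carboxymethyl in place of bromo on an aromatic carbon. For the measured compounds named here, no measured step exchanges bromo, or any group, for carboxymethyl; the only readable steps from compound 2 lead to a 3-methylphenyl, and they say nothing about this change. An expectation for compound 4 in this assay therefore rests on compound 2 alone: the number is expected to stay near its limit, with the step of an at least 1.2-fold lower number from compound 2 to compound 4 (0.09 log units; that floor lies within the scatter) as the estimate. Compound 4 is estimated at 800 umol/kg, within 150 umol/kg to 3000 umol/kg.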

Compound 4, dose for 50% inhibition: > 100 umol/kg
Compound 4: no number, only a limit; the forecaster's own chance of this, stated with the estimate: 60%; the middle value lies beyond the limit too.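

In this assay compound 4 gives > 100 umol/kg as a limit of the assay and not a number. For the compounds shown here, compound 2 gives > 1000 umol/kg as a limit too, so no step from compound 2 to compound 4 can be read. The compounds shown leave open whether carboxymethyl in place of bromo changes the dose needed in this assay at all.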